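Ring substitution pattern on the acid-bearing aryl ether

This account rests on a few compounds, and the source may have more. Where it says the series, first, only, none or still open, it means among the compounds named here.

Compound 3 `Cc1c(OC[C@@H](C)COc2cc(C(=O)O)ccc2F)ccc(C(=O)CC(C)(C)C)c1O` gives 3950 nM in an assay for positive allosteric modulation of metabotropic glutamate receptor 3 (Rattus norvegicus) (on this read-out higher numbers stand for an effect only at larger amounts of compound and lower numbers for an effect already at smaller amounts), the highest of the three numbers measured. Compound 1 `Cc1c(OC[C@@H](C)COc2ccc(F)c(C(=O)O)c2)ccc(C(=O)CC(C)(C)C)c1O` gives 1180 nM and compound 2 `COc1ccc(C(=O)O)cc1OC[C@H](C)COc1ccc(C(=O)CC(C)(C)C)c(O)c1C` gives 384 nM. The step of a 3.3-fold higher number from compound 1 to compound 3 (0.52 log units; beyond the scatter) shows a change of substituent pattern on the aryl ether; the step of a 10-fold higher number from compound 2 to compound 3 (1.01 log units; beyond the scatter) shows fluoro replacing methoxy. Compound 4 `Cc1ccc(OC[C@H](C)COc2ccc(C(=O)CC(C)(C)C)c(O)c2C)cc1C(=O)O` differs from compound 3 by 3-carboxy-4-methylphenyl in place of 5-carboxy-2-fluorophenyl on an oxygen on a saturated carbon, restoring a pattern of acid and neighbouring group closer to that of compound 1 and compound 2. Both steps bear on this change, so a lower number is expected for compound 4, estimated at 900 nM (range 300 nM to 2700 nM), corresponding to an expected step of a 4.4-fold lower number from compound 3 to compound 4 (0.64 log units; beyond the scatter).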

Compound 4, half-maximal effective concentration: > 10000 nM
Compound 4 gave a limit, no number; the forecaster's own chance of this, stated with the estimate: 5%; middle value at least 11-fold (1.04 log units) from the limit.
By their numbers in this assay, from the lowest: compound 2; then compound 1; then compound 3. At a limit, above all of these: compound 4.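

In this assay compound 4 gives > 10000 nM as a limit of the assay, not a number. Replacing 5-carboxy-2-fluorophenyl with 3-carboxy-4-methylphenyl gives an at least 2.5-fold higher number from compound 3 to compound 4 (0.40 log units; beyond the scatter) and so recovers nothing, although both groups have the same heavy-atom count. Methyl in place of fluoro on an aromatic carbon gives an at least 8.4-fold higher number from compound 1 to compound 4 (0.92 log units; beyond the scatter) as well, so the pattern shared with compound 1 does not hold the read-out once this one group changes.

As far as these compounds go, how far compound 4 lies past its limit stays open, so the full size of both steps remains unknown. From the compounds shown here alone, whether a chloro or hydroxyl group in place of that methyl would track fluoro or methyl also stays open.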